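The compounds below may be only part of what the source reports. "The series", "measured", "known", "first", "only" and "open" are said of these compounds alone.

Measured compounds:
- Compound 1, `CCN1CC(CC#N)(n2cc(-c3nc(-c4cnn(C)c4)cn4nccc34)cn2)C1`, in an ADME assay on microsomes from liver (Homo sapiens) for pharmacokinetics (a higher number here means faster removal of the compound, a lower number slower removal), compound 1 gives 21 uL/min
- Compound 2, `Cn1ccc(-c2cn3nccc3c(-c3cnn([C@]4(CC#N)C[C@H](C#N)C4)c3)n2)n1`, in this assay compound 2 gives 23 uL/min

Compound 2 has the higher of the two numbers, but its gap to compound 1 lies within the usual scatter of this assay, so the two compounds cannot be told apart on these data; they show much the same rate of removal.

Compound 3, `N#CC[C@]1(n2cc(-c3nc(-c4cn[nH]c4)cn4nccc34)cn2)C[C@@H](C#N)C1`, has not yet been measured. It differs from compound 2 in one place: 1H-pyrazol-4-yl in place of 1-methyl-1H-pyrazol-3-yl on an aromatic carbon. Among the measured compounds shown here, no step between measured compounds speaks to such a change, so there is no direct guide to its effect here.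

For the measured compounds named here, with only this pair of closely matched values to go on, the step from compound 2 to compound 3 is expected to stay within the scatter, a 1.2-fold lower number from compound 2 to compound 3 (0.06 log units; within the scatter), with no clear direction. Compound 3 is therefore estimated at 20 uL/min, in a range from 10 uL/min to 40 uL/min.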

Compound 3, intrinsic clearance in a liver preparation (reported as CLH), per the amount of preparation that the assay uses in the Homo sapiens assay: 44 uL/min
The estimate for compound 3 lay 2.2-fold (0.34 log units) below the measured number; measured number outside the range, above it.
By their numbers in the Homo sapiens assay, from the lowest: compounds 1, 2 and 3 (each within the scatter of the next, the first and the last beyond it).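

This position tolerates the swap on the evidence so far: in the Homo sapiens assay the change gives a 1.9-fold higher number from compound 2 to compound 3 (0.28 log units; within the scatter), so replacing 1-methyl-1H-pyrazol-3-yl with 1H-pyrazol-4-yl, which brings in a hydrogen-bond donor, does not clearly separate the two compounds in removal rate. In a physicochemical assay for lipophilicity, using the shake flask method, in phosphate buffer, measured as octanol-water partition, at pH 7.4 (a higher number here means a more lipophilic compound, a lower number a more polar compound), compound 2 gives 1.6 and compound 3 gives 1.6, which is no change at the digits printed from compound 2 to compound 3 (within the scatter), so the swap leaves this measure of lipophilicity unmoved. No supporting data here explain these results.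

The swap removes the methyl group and also changes how the pyrazole is attached, and these two parts cannot be told apart here. From the compounds shown here alone, whether a different group at this position, such as an amine or a carboxylic acid, would shift either number also remains open.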